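The compounds below may be only part of what the source reports. "The series", "measured", "known", "first", "only" and "open" are said of these compounds alone.

Working notes on the series, all read in a functional assay on B16 cells (Mus musculus) for inhibition, with a stated time of 72 h; on this read-out lower numbers stand for stronger inhibition and higher numbers for weaker inhibition. Compound 1 (`COc1ccc(CN2CCNC2=S)cc1`) gives > 10000 nM, which is a limit and not a number. Compound 3 (`O=C1NCCCN1Cc1ccccc1`) gives > 10000 nM, again only a limit. These two entries make up (the limit of > 10000 nM in this assay, at which 2 of the 3 values shown sit), so the position of compound 3 is bounded on one side only. Going by the values given here, the single numerical value in the set comes from compound 2 (`CCc1ccc(CN2CCCNC2=S)cc1`), at 1300 nM.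

Compound 4 (`CCc1ccc(CN2CCCNC2=O)cc1`) is compound 3 with ethyl in place of hydrogen on an aromatic carbon. Among the compounds with values here, no measured pair shows the size of this change. Compound 2 also carries an ethyl group and gives 1300 nM, which suggests that compound 4 may give a measurable value. The expected change is toward stronger inhibition, but its size is poorly defined, and a further limit reading remains possible. The estimated step is an at least 2.2-fold lower number from compound 3 to compound 4 (0.34 log units; beyond the scatter). For compound 4 the estimated value is 4500 nM, with an expected range of 1500 nM to 10000 nM.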

Compound 4, half-maximal inhibitory concentration: > 10000 nM
Compound 4 gave a limit, no number; the forecaster's own chance of this, stated with the estimate: 40%; middle value at least 2.2-fold (0.34 log units) away from the limit.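

No step can be read from compound 3 to compound 4, because both readings are limits and not numbers: the limit of > 10000 nM in this assay, at which 3 of the 4 values shown sit.

The compounds shown leave open whether ethyl in place of hydrogen on an aromatic carbon changes inhibition at all, and by how much.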